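Dropping One Chloro Group: Expected Cytotoxicity of Compound 4

The source may hold more compounds than are shown below. What is called first, only, known or untested is meant among the compounds shown, and "the series" means these compounds.

Measured compounds:
compound 1, `Cn1cc(SCC(=O)Nc2ccc(Cl)c(Cl)c2)c2ccccc21`: > 100000 nM
compound 2, `Cn1cc(SCC(=O)Nc2c(Cl)cccc2Cl)c2ccccc21`: > 100000 nM
compound 3, `CCOc1ccccc1NC(=O)CSc1c[nH]c2cc(OC)ccc12`: 88200 nM

Three compounds were tested in an ADME assay on HEK-293T cells (Homo sapiens) for cytotoxicity, read by CCK-8 assay, with a stated time of 48 h; on this read-out higher numbers stand for lower toxicity in this test and lower numbers for higher toxicity in this test. Compound 1 gives > 100000 nM, which is a limit of the assay and not a number. Compound 2 likewise reaches only a limit, > 100000 nM. For the measured compounds named here, compound 3 is the one compound with a number, giving 88200 nM in this assay. Compound 1 therefore stands at the limit of > 100000 nM in this assay, at which 2 of the 3 values shown sit, and one further value shown is also a limit, so no ordering among these compounds can be drawn from the figures themselves.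

Compound 4, `Cn1cc(SCC(=O)Nc2ccc(Cl)cc2)c2ccccc21`, has not yet been measured. It differs from compound 1 by hydrogen in place of chloro on an aromatic carbon. Going by the values given here, no pair of measured compounds differing in one place is available, so the size of this step cannot be read from the data. Given that compound 1 sits at a limit, the step from compound 1 to compound 4 in this assay is expected to be none beyond the scatter, a step that the limit leaves unreadable from compound 1 to compound 4. Compound 4 is accordingly estimated to give 150000 nM, within 70000 nM to 350000 nM, most likely again reported only as a limit.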

Compound 4, half-maximal cytotoxic concentration: > 100000 nM
Compound 4: no number, only a limit (the forecaster's own chance of this, stated with the estimate: 75%); the middle value does not contradict the limit.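

In this assay compound 4 gives > 100000 nM as a limit and not a number. Compound 1 likewise gives > 100000 nM as a limit, so no step can be read from compound 1 to compound 4. The compounds shown leave open how far hydrogen in place of chloro on an aromatic carbon shifts this read-out, if at all: the limit of > 100000 nM in this assay, at which 3 of the 4 values shown sit.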